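The compounds below may be only part of what the source reports. "The series", "measured", "known", "first", "only" and "open" are said of these compounds alone.

Measured in a functional assay on HeLa cells (Homo sapiens) for inhibition, read by CCK-8 assay, with a stated time of 72 h (a lower number here means a stronger inhibitor, a higher number a weaker inhibitor), the compounds read as follows
Compound 1 `O=C(/C=C/c1cccnc1)NCCCCCc1ccc(S(=O)(=O)Nc2ccccc2)cc1` gives 333 nM
Compound 2 `O=C(/C=C/c1cccnc1)NCCCCCCc1ccc(S(=O)(=O)Nc2ccccc2)cc1` gives 377 nM
Compound 3 `Cc1ccc(NS(=O)(=O)c2cccc(CCCCCCNC(=O)/C=C/c3cccnc3)c2)cc1` gives 38.8 nM

Compound 3 holds the lowest number of the three, and the values of compound 1 and compound 2 both lie above it, beyond the scatter. Compound 4 `CCc1ccc(NS(=O)(=O)c2cccc(CCCCCCNC(=O)/C=C/c3cccnc3)c2)cc1` has not yet been measured. The change methyl in place of hydrogen on a saturated chain carbon bound to an aromatic carbon places methyl on a saturated chain carbon bound to an aromatic carbon, turning 4-methylphenyl to 4-ethylphenyl. Within the data shown here, no measured pair differs in one place, so this expectation rests on the small size of the change alone: no step beyond the scatter is expected in this assay for this change. The estimated step of a 1.2-fold higher number from compound 3 to compound 4 (0.06 log units; within the scatter) stays small. Compound 4 is expected at 45 nM within an estimated range from 18 nM to 110 nM in this measurement.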

Compound 4, half-maximal inhibitory concentration: 132 nM
Beside the measured number, compound 4's estimate is 2.9-fold (0.47 log units) below it; measured number outside the range, above it.
By their numbers in this assay, from the lowest: compound 3; then compound 4; then compounds 1 and 2 (each within the scatter of the next).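

In this assay, the one added methyl that turns 4-methylphenyl to 4-ethylphenyl gives a 3.4-fold higher number from compound 3 to compound 4 (0.53 log units; beyond the scatter) and compound 4 is the weaker inhibitor. This first step between compounds differing in one place shows that even so small a change, on a saturated chain carbon bound to an aromatic carbon, registers in this assay. No measured evidence bears on why the number rises.
Still open, from the compounds shown here alone, is whether a longer chain such as propyl would raise the number further. Going by these compounds, how an amine or a carboxylic acid on this carbon would read also remains open.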